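A few compounds are considered here, and "the series" means these few. Any claim that something is new, unique, unknown or untested is made for them only; others in the source may bear on it.

Measured so far:
compound 1, `COc1ccc(C(=O)/C(=C/c2ccc(Cl)cc2)CCOC(C)=O)cc1` — in a functional assay on NB-4 cells (Homo sapiens) for inhibition, read by XTT assay, with a stated time of 48 h (a lower number here means a stronger inhibitor, a higher number a weaker inhibitor), compound 1 gives 36300 nM
compound 2, `COc1ccc(C(=O)/C(=C/c2ccc(Cl)cc2Cl)CC(C)C)cc1` — in this assay compound 2 gives 14600 nM
compound 3, `COc1ccc(C(=O)/C(=C/c2ccc([N+](=O)[O-])cc2)CC(C)C)cc1` — in this assay compound 3 gives 600 nM

Compound 3 has the lowest number of the three; compound 2 is nearest and compound 1 furthest, both gaps well beyond the scatter. Compound 4, `COc1ccc(C(=O)/C(=C/c2ccc(Cl)cc2)CC(C)C)cc1`, is not yet measured in this assay. It differs from compound 3 in one place: chloro in place of nitro on an aromatic carbon. Among the measured compounds shown here, no measured pair isolates this change. The two chloro-bearing compounds, compound 1 and compound 2, both carry far higher numbers than compound 3, though neither differs from compound 4 in the same single place. The step from compound 3 to compound 4 is expected to be a clear rise, a 13-fold higher number from compound 3 to compound 4 (1.12 log units; beyond the scatter). For compound 4 in this assay the estimate is 8000 nM, within 1500 nM to 40000 nM.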

Compound 4, half-maximal inhibitory concentration: 12100 nM
For compound 4 the middle estimate is 1.5-fold (0.18 log units) below the measured one, within the range that was stated.
By their numbers in this assay, from the lowest: compound 3; then compounds 4 and 2 (each within the scatter of the next); then compound 1.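

In this assay the swap of nitro for chloro on the aromatic carbon para to a large group is now isolated, and it is a large step (a 20-fold higher number from compound 3 to compound 4 (1.30 log units; beyond the scatter)). The other two single changes count for far less: removing the second chloro stays within the scatter (a 1.2-fold lower number from compound 2 to compound 4 (0.08 log units; within the scatter)), and isopropyl in place of acetoxymethyl is modest (a 3.0-fold lower number from compound 1 to compound 4 (0.48 log units; beyond the scatter)). No measurement at hand explains the nitro step.

Still open, from the compounds shown here alone, is whether this step is specific to nitro: a nitrile, an amine or a carboxylic acid at this position would test that. A longer chain in place of isopropyl is also untested here.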